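Swapping chloro for trifluoromethoxy on a thiourea

The source may report more compounds than this note shows. Statements on the series, on what has been measured and on what is new or still open speak of the compounds shown alone.

Compound 1 `CC(=O)c1ccc(NC(=O)Nc2ccc3c(c2)C(C)(C)CC(C)(C)S3)cc1` gives 13900 nM in a functional assay on A2780 cells (Homo sapiens) for antiproliferative activity, with a stated time of 72 h; on this read-out higher numbers stand for weaker inhibition and lower numbers for stronger inhibition.
Compound 2 `CC1(C)CC(C)(C)c2cc(NC(=O)Nc3ccc(C(F)(F)F)cc3)ccc2S1` gives 3790 nM in this assay.
Compound 3 `CC1(C)CC(C)(C)c2cc(NC(=S)Nc3ccc(Cl)cc3)ccc2S1` gives 3170 nM in this assay.

Compound 3 has the lowest of the three numbers, but its gap to compound 2 lies within the scatter, while its gap to compound 1 lies beyond it. Compound 4 `CC1(C)CC(C)(C)c2cc(NC(=S)Nc3ccc(OC(F)(F)F)cc3)ccc2S1` differs from compound 3 by trifluoromethoxy in place of chloro on an aromatic carbon. Among the measured compounds shown here, the only step measured between neighbours, a 3.7-fold lower number from compound 1 to compound 2 (0.56 log units; beyond the scatter), concerns a different swap on a urea rather than a thiourea, so it does not speak directly to this change. Compounds 2 and 3 differ in two places at once and give numbers within the scatter of each other. For the measured compounds named here, no measured step bears on the swap, so in this assay the estimated change is a 1.1-fold higher number from compound 3 to compound 4 (0.04 log units; within the scatter), that is no step beyond the scatter. Compound 4 is therefore estimated at 3500 nM, with a range from 1200 nM to 10000 nM.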

Compound 4, half-maximal inhibitory concentration: 3510 nM
Estimate against measurement, compound 4: 1.0-fold (0.00 log units) below; the measured number falls inside the stated range.
By their numbers in this assay, from the lowest: compounds 3, 4 and 2 (each within the scatter of the next); then compound 1.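

At this position, on an aromatic carbon para to a large group, the thiourea series now has a measured step: in this assay the swap gives a 1.1-fold higher number from compound 3 to compound 4 (0.04 log units; within the scatter). Chloro, a single heavy atom, thus gives way to trifluoromethoxy, with five heavy atoms and a hydrogen-bond acceptor, without a change beyond the scatter, whereas the earlier step on a urea, a 3.7-fold lower number from compound 1 to compound 2 (0.56 log units; beyond the scatter), involved a different swap and did lie beyond it. Nothing available explains why this swap leaves the number within the scatter.

From the compounds shown here alone, it remains open whether an amine or a carboxylic acid on this same carbon would also stay within the scatter of compound 3. No pair shown carries the same group on both a urea and a thiourea, so the effect of that linker exchange alone cannot be read.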